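The source may report more compounds than this note shows. Statements on the series, on what has been measured and on what is new or still open speak of the compounds shown alone.

Compound 1 `COc1ccc(C2CC(Nc3nc4ccc(C)cc4s3)=NN2C(C)=O)cc1`: 39.4 umol/kg
Compound 2 `CC(=O)N1N=C(Nc2nc3ccc(C)cc3s2)CC1c1ccc(O)cc1`: 54.3 umol/kg
Compound 3 `CC(=O)N1N=C(Nc2nc3ccc(C)cc3s2)CC1OC1=CC=C1`: "not determined" (no result reported)
Compound 4 `COc1ccc(C2CC(Nc3nc4ccc(Cl)cc4s3)=NN2C(C)=O)cc1`: not yet measured

In a functional assay on the whole organism (strain albino) with Mus musculus as the target, with a stated time of 0.5 h (a higher number here means that more compound is needed for the effect, a lower number that less compound is needed), compound 1 gives 39.4 umol/kg. Going by the values given here, only one other number is available for comparison: compound 2 gives 54.3 umol/kg, and these two values lie within the scatter of each other. Compound 3 has no number to compare, as its entry reads "not determined" (no result reported).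

The next compound changes one group of compound 1. Compound 4 differs from compound 1 in that group alone (chloro in place of methyl on an aromatic carbon). Among the compounds with values here, the only measured step, a 1.4-fold higher number from compound 1 to compound 2 (0.14 log units; within the scatter), swaps a methyl on an oxygen for hydrogen, so it concerns a different place in the molecule. Within the data shown here, no measured step touches the place that changes here. That single step stayed small, but it offers only weak guidance, so no shift beyond the scatter is expected in this assay, and no direction can be favoured with confidence. The estimate implies a 1.1-fold lower number from compound 1 to compound 4 (0.05 log units; within the scatter), which is expected to stay within the scatter. For compound 4 the estimated value is 35 umol/kg, with an expected range from 14 umol/kg to 90 umol/kg.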

Compound 4, dose for half-maximal effect: 97.3 umol/kg
The estimate for compound 4 lay 2.8-fold (0.44 log units) below the measured number, and the stated range ends below it.
By their numbers in this assay, from the lowest: compounds 1, 2 and 4 (each within the scatter of the next, the first and the last beyond it).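

In this assay, chloro in place of methyl on this aromatic carbon gives a 2.5-fold higher number from compound 1 to compound 4 (0.39 log units; beyond the scatter), so more compound is needed for the effect. Going by these compounds alone, this is the first sign that this position of the fused two-ring system matters, since the only earlier step, at the oxygen on the other aromatic ring, gives a 1.4-fold higher number from compound 1 to compound 2 (0.14 log units; within the scatter). The shift is modest, and nothing available gives a reason for it.

The compounds shown leave open whether the methyl is specially suited to this position or whether other groups, such as an amine or a longer chain, would bring the number back down or push it further up. They also leave open whether chloro would have the same effect with a hydrogen in place of the methyl on the oxygen, as in compound 2.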